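Replacing 1-methylazetidin-3-yl with 1-methylpyrrolidin-3-yl in compound 3

This account rests on a few compounds, and the source may have more. Where it says the series, first, only, none or still open, it means among the compounds named here.

Going by the values given here, in an ADME assay on HOS cells (Homo sapiens) for cytotoxicity (a higher number here means that more compound is tolerated, a lower number that less compound is tolerated), compound 1 `CN1CCCC(Cn2c(CN(C)C3CCCc4cccnc43)nc3ccccc32)C1` gives 3000 nM and compound 2 `CN1CC(Cn2c(CN(C)C3CCCc4cccnc43)nc3ccccc32)C1` gives 14000 nM, the higher of the two numbers so far. Among the compounds with values here, one measured step bears on the next change: a 4.7-fold higher number from compound 1 to compound 2 (0.67 log units; beyond the scatter), with 1-methylazetidin-3-yl in place of 1-methylpiperidin-3-yl on a saturated chain carbon bound to an aromatic nitrogen. Compound 3 `CN1CCC(Cn2c(CN(C)C3CCCc4cccnc43)nc3ccccc32)C1` is altered at that same place: 1-methylpyrrolidin-3-yl in place of 1-methylazetidin-3-yl on a saturated chain carbon bound to an aromatic nitrogen. Its ring size is intermediate to those of the two measured groups, so the values of compound 1 at 3000 nM and compound 2 at 14000 nM offer a rough frame. Two points cannot show that the number follows ring size smoothly, so this reading is an assumption. A fall from compound 2 is expected, smaller than the measured step, and it may not clear the scatter by much. The estimated change is a 2.2-fold lower number from compound 2 to compound 3 (0.33 log units; beyond the scatter). For compound 3 the estimated value is 6500 nM, with an expected range of 2500 nM to 14000 nM.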

Compound 3, half-maximal cytotoxic concentration: 15000 nM
Estimate against measurement, compound 3: 2.3-fold (0.36 log units) below; measured number above the stated range.
By their numbers in this assay, from the lowest: compound 1; then compounds 2 and 3 (each within the scatter of the next).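

In this assay, 1-methylpyrrolidin-3-yl in place of 1-methylazetidin-3-yl gives a 1.1-fold higher number from compound 2 to compound 3 (0.03 log units; within the scatter), so on a saturated chain carbon bound to an aromatic nitrogen these two rings cannot be told apart in this read-out. Set against 1-methylpiperidin-3-yl, the same group gives a 5.0-fold higher number from compound 1 to compound 3 (0.70 log units; beyond the scatter), so the three compounds do not form a graded run with ring size: compound 2 and compound 3 stand together, and compound 1 alone stands apart with the lower number. No measured evidence on these compounds accounts for this grouping.

The compounds shown leave open whether the separation belongs to 1-methylpiperidin-3-yl specifically or to piperidine rings more widely, which 1-methylpiperidin-4-yl or an unsubstituted piperidin-3-yl at the same place would help to settle. They also leave open whether a ring is needed here at all, since every compound in the set carries a cyclic amine, and an open-chain group such as 2-(dimethylamino)ethyl on the same aromatic nitrogen would test that in this assay.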